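A few compounds are considered here, and "the series" means these few. Any claim that something is new, unique, unknown or untested is made for them only; others in the source may bear on it.

Compound 1 `COc1cc(C(c2ccc(O)c(OC)c2)[C@@H](C)[C@H](C)CO)ccc1O`: > 100000 nM
Compound 2 `CCCCCCCC[C@H](C(C)C)C(c1ccc(O)c(OC)c1)c1ccc(O)c(OC)c1`: 3100 nM
Compound 3 `COc1ccc(C(c2ccc(OC)c(OC)c2)[C@@H](C)[C@@H](C)CO)cc1OC`: > 100000 nM

The three measured compounds share a core in which one saturated carbon carries two aromatic rings, and they differ in the chain attached to that carbon. In a functional assay on HeLa cells (Homo sapiens) for cytotoxicity, read by WST assay, with a stated time of 48 h (a lower number here means a stronger inhibitor, a higher number a weaker inhibitor), compound 2 gives 3100 nM. For compound 1 the reading is a limit of the assay, > 100000 nM. For compound 3 the reading is likewise a limit, > 100000 nM. Compound 1 thus stands at the limit of > 100000 nM in this assay, at which 2 of the 3 values shown sit, so no number is known for it, while compound 2 is the only one of the three with a measured value.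

Compound 4 `COc1cc(C(c2ccc(O)c(OC)c2)[C@@H](CF)C(C)C)ccc1O` is not yet measured. It differs from compound 1 in one place: 1-(fluoromethyl)-2-methylpropyl in place of 2-(hydroxymethyl)-1-methylpropyl on a saturated chain carbon bound to two aromatic carbons. Going by the values given here, no measured pair shows this kind of change, so the size of the step can only be guessed. Since compound 1 gives only a limit, any measurable value for compound 4 would appear as a move toward stronger inhibition, but it is also possible that compound 4 remains at the limit.

Compound 4 is expected to give about 40000 nM in this assay, with a likely range from 8000 nM to 150000 nM. This corresponds to an expected step of an at least 2.5-fold lower number from compound 1 to compound 4 (0.39 log units; beyond the scatter).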

Compound 4, half-maximal inhibitory concentration: 41000 nM
The estimate for compound 4 lay 1.0-fold (0.01 log units) below the measured number; the measured number falls inside the stated range.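

Going by these compounds alone, at the position on a saturated chain carbon bound to two aromatic carbons, the earlier compounds offered no step that could be read, and this change now provides one in this assay. Putting 1-(fluoromethyl)-2-methylpropyl in place of 2-(hydroxymethyl)-1-methylpropyl gives an at least 2.4-fold lower number from compound 1 to compound 4 (0.38 log units; beyond the scatter), with the heavy-atom count of the chain unchanged while its hydrogen-bond donor and hydrogen-bond acceptor are lost. This step is a bound and not a full size, because the reading for compound 1 is only a limit: the limit of > 100000 nM in this assay, at which 2 of the 4 values shown sit.

The compounds shown leave open whether the step belongs to the fluorine, to the loss of the hydroxyl or to the altered arrangement of the chain, as all three changes fall within this single replacement, which also leaves one defined stereocentre in place of two. As far as these compounds go, how an amine at the end of this chain, or a longer chain carrying fluorine, would read at this position also remains open.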